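The source may report more compounds than this note shows. Statements on the series, on what has been measured and on what is new or still open speak of the compounds shown alone.

Working notes on the series. The shared core is carried in compound 3 `CCCOc1ccc(C[C@@H](Cc2ccccc2)C(=O)O)cc1CNC(=O)c1ccc(-c2cccnc2)cc1`, and the property followed is a physicochemical assay for solubility, read by HPLC, in phosphate buffer, measured as thermodynamic solubility, with a stated time of 48 h, at pH 7.2; a lower number here means a less soluble compound, a higher number a more soluble compound. Compound 1 `CCCOc1ccc(C[C@@H](Cc2ccccc2)C(=O)O)cc1CNC(=O)c1ccc(-c2cncnc2)cc1` gives 190 ug/mL in this assay. Compound 2 `CCCOc1ccc(C[C@@H](Cc2ccccc2)C(=O)O)cc1CNC(=O)c1ccc(-c2ccccc2F)cc1` returns only a limit in this assay, < 1 ug/mL, which is the limit of < 1 ug/mL in this assay, at which 1 of the 3 values shown sits. Within the data shown here, compound 3 gives 69.5 ug/mL in this assay, the lowest of the two numbers so far, with compound 1 as its nearest neighbour. The step of a 2.7-fold lower number from compound 1 to compound 3 (0.44 log units; beyond the scatter) is modest, whereas an at least 190-fold lower number from compound 1 to compound 2 (2.27 log units; beyond the scatter) and an at least 69-fold higher number from compound 2 to compound 3 (1.84 log units; beyond the scatter) are both large.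

Compound 4 `CCCOc1ccc(C[C@@H](Cc2ccccc2)C(=O)O)cc1CNC(=O)c1ccc(-c2ccccn2)cc1` differs from compound 3 by pyridin-2-yl in place of pyridin-3-yl on an aromatic carbon. Among the measured compounds shown here, no measured step covers this exchange directly: the measured steps swap one six-membered ring for another of a different kind, and the only comparison between two heteroaryl rings of this kind, a 2.7-fold lower number from compound 1 to compound 3 (0.44 log units; beyond the scatter), is modest. On that basis the exchange is expected to give a step in this assay of about a 1.7-fold lower number from compound 3 to compound 4 (0.24 log units; within the scatter), and a result within the scatter of compound 3 would not be surprising. Compound 4 is therefore estimated at 40 ug/mL in this assay, with a range from 10 ug/mL to 120 ug/mL.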

Compound 4, solubility: 17 ug/mL
Estimate against measurement, compound 4: 2.4-fold (0.37 log units) above; measured number inside the range.
By their numbers in this assay, from the lowest: compound 4; then compound 3; then compound 1. At a limit, below all of these: compound 2.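

In this assay, the exchange of pyridin-3-yl for pyridin-2-yl, on an aromatic carbon para to a large group, leaves the atoms unchanged and alters only how they are joined, yet it gives a 4.1-fold lower number from compound 3 to compound 4 (0.61 log units; beyond the scatter), so the place of the ring nitrogen alone moves the number beyond the scatter. Among these compounds, no earlier step could show this. Each of those steps also changed the ring atoms. Among the three nitrogen-bearing rings the order now runs from pyrimidin-5-yl down through pyridin-3-yl to pyridin-2-yl, with an 11-fold lower number from compound 1 to compound 4 (1.05 log units; beyond the scatter) for the full span, while pyridin-2-yl still keeps a wide margin over 2-fluorophenyl, at an at least 17-fold higher number from compound 2 to compound 4 (1.23 log units; beyond the scatter). That last step is a bound and not a measured size, since compound 2 stands at a limit of the assay: the limit of < 1 ug/mL in this assay, at which 1 of the 4 values shown sits.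

Pyridin-4-yl, the remaining isomer of this ring, is not among the compounds shown, so it stays open whether the trend with nitrogen placement carries on to it. Also open is what an amine or a methoxy group on the pyridine ring would do at this position, and the numbers here give no reason for the order seen.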